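Acid-to-amide exchange on the phenoxybenzyl aniline series

The compounds below may be only part of what the source reports. "The series", "measured", "known", "first", "only" and "open" are said of these compounds alone.

Compound 2 `O=C(O)CCCc1ccc(NCc2cccc(Oc3ccccc3)c2)cc1` gives the highest of the two numbers in a functional assay on CHO cells for agonist activity at Free fatty acid receptor 1 (Homo sapiens) (a higher number here means that more compound is needed for the effect, a lower number that less compound is needed), at 1120 nM; compound 3 `Cc1nc(-c2ccc(C(F)(F)F)cc2)sc1CNc1ccc(C(C)CC(=O)O)cc1` gives 58.9 nM. Compound 1 `Cc1nc(-c2ccc(C(F)(F)F)cc2)sc1CNc1ccc(CC(=O)O)cc1` gives only a limit in this assay, < 10000 nM. The step that the limit leaves unreadable from compound 1 to compound 3 is thus unreadable because of the limit of < 10000 nM in this assay, at which 1 of the 3 values shown sits. Compound 4 `NC(=O)CCc1ccc(NCc2cccc(Oc3ccccc3)c2)cc1` differs from compound 2 by carbamoyl in place of carboxymethyl on a saturated chain carbon, two bonds along the chain from an aromatic carbon. For the measured compounds named here, no measured step covers an exchange of the acid for an amide; the single recorded step concerns a different change on a different core, so it does not bear on this one. The expectation for compound 4 rests on compound 2 alone and carries a wide range: a weakening step a 5.4-fold higher number from compound 2 to compound 4 (0.73 log units; beyond the scatter) is estimated. Compound 4 is expected to give 6000 nM in this assay, between 1200 nM and 30000 nM.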

Compound 4, half-maximal effective concentration: 51.3 nM
Compound 4: the middle estimate sits 120-fold (2.07 log units) above what was measured; the whole stated range lies above it.
By their numbers in this assay, from the lowest: compounds 4 and 3 (each within the scatter of the next); then compound 2.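

On this core, the exchange of 3-carboxypropyl for 2-carbamoylethyl gives a 22-fold lower number from compound 2 to compound 4 (1.34 log units; beyond the scatter) in this assay. A carboxylic acid on this chain is therefore not required for agonist activity, and the carbamoyl end is the better of the two at this position. Nothing measured here gives a reason for this step.

The change alters the chain end and the chain length together, so a 2-carboxyethyl or 3-carbamoylpropyl chain would be needed to separate the two. As far as these compounds go, how a nitrile or an amine would fare at this position stays open.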